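Chain extension by one methyl in an antagonist series

This account rests on a few compounds, and the source may have more. Where it says the series, first, only, none or still open, it means among the compounds named here.

Compound 1 `Cn1c(-c2ccccc2)nnc1S(C)(=O)=O` and compound 2 `CCS(=O)(=O)c1nnc(-c2ccccc2)n1C` share one core and differ in a single place. Compound 3 `CSc1nnc(-c2ccc(Cl)cc2)n1C` carries a different core; the difference between the two cores is not broken down here. Compound 4 `CCn1c(SC)nnc1-c1ccc(Cl)cc1` is not yet measured and stands to compound 3 as compound 2 stands to compound 1.

In a functional assay on the whole organism for antagonist activity, with Mus musculus as the target (a lower number here means that less compound is needed, a higher number that more compound is needed for the effect), compound 1 gives 12.8 mg/kg. In this assay compound 2 gives 19.3 mg/kg. In this assay compound 3 gives 28.1 mg/kg, which lies within the scatter of compound 2 but beyond the scatter of compound 1.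

The measured change is methyl in place of hydrogen on a saturated chain carbon bound to a sulfonyl sulfur It made a 1.5-fold higher number from compound 1 to compound 2 (0.18 log units; within the scatter). The change still to be measured is methyl in place of hydrogen on a saturated chain carbon bound to an aromatic nitrogen The two places are not the same word for word: in the first the saturated chain carbon is bound to a sulfonyl sulfur, in the second to an aromatic nitrogen. It is therefore the same kind of change, not the same change. Among the compounds here it occurs two times, once with a measurement.

With only one measured case to rest on, the expected step from compound 3 to compound 4 is a 1.4-fold higher number from compound 3 to compound 4 (0.13 log units; within the scatter), a small move like a 1.5-fold higher number from compound 1 to compound 2 (0.18 log units; within the scatter), expected to stay within the scatter. Compound 4 is estimated at 38 mg/kg in this assay, with the range 18 mg/kg to 80 mg/kg reflecting that the place of the change differs from the measured case.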

Compound 4, dose for half-maximal effect: 26.7 mg/kg
Compound 4: the middle estimate sits 1.4-fold (0.15 log units) above what was measured; the range from low to high includes it.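

In this assay, methyl in place of hydrogen on a saturated chain carbon bound to an aromatic nitrogen gives a 1.1-fold lower number from compound 3 to compound 4 (0.02 log units; within the scatter). Set beside the case on the saturated chain carbon bound to a sulfonyl sulfur, the two steps do not differ by more than the scatter allows: the same change on two cores in this assay, a 1.5-fold higher number (0.18 log units; within the scatter) from compound 1 to compound 2 and a 1.1-fold lower number (0.02 log units; within the scatter) from compound 3 to compound 4, 1.6-fold (0.20 log units) apart, within the scatter of two such steps. This shows that, in these two cases, methyl to ethyl left the dose within the scatter on both cores; it does not show a rule for the series, as two pairs are few, and core and place change together between them, so the effect of either one alone cannot be read.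

Also unsettled is how far such chains can grow at either place: a longer chain such as propyl or butyl might still stay within the scatter or might move the dose beyond it. A polar end on the chain, such as an amine or a carboxylic acid, remains equally open, and the compounds shown give no basis for carrying the flat result from methyl to ethyl over to any of these groups.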